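From isopropylamino to morpholin-4-yl on a sulfonyl sulfur

This account rests on a few compounds, and the source may have more. Where it says the series, first, only, none or still open, it means among the compounds named here.

Measured in an in vitro ADME assay on microsomes from liver (Homo sapiens) for metabolic stability, read by LC-MS, tested at 1 uM; on this read-out lower numbers stand for slow clearance and higher numbers for fast clearance:
- Compound 1 `Cc1ccc(S(=O)(=O)N(C)C(C)C)cc1C#Cc1cc(Cl)ccc1OCC(=O)O`: < 10 mL.min-1.g-1, a limit of the assay
- Compound 2 `Cc1ccc(S(=O)(=O)NC(C)C)cc1C#Cc1cc(Cl)ccc1OCC(=O)O`: < 10 mL.min-1.g-1, a limit of the assay

Compound 2 has no exact number on this scale, only a limit. Compound 1 is no better defined, so the whole of the evidence is the limit of < 10 mL.min-1.g-1 in this assay, at which 2 of the 2 values shown sit.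

The next compound to be measured is compound 3 `Cc1ccc(S(=O)(=O)N2CCOCC2)cc1C#Cc1cc(Cl)ccc1OCC(=O)O`, which carries morpholin-4-yl in place of isopropylamino on a sulfonyl sulfur. For the measured compounds named here, only one measured step bears on this change, and it is a step that the two limits leave unreadable from compound 1 to compound 2. That step swaps just a methyl and a hydrogen on a sulfonamide nitrogen, and its size cannot be read. It therefore offers no measured guide to the effect of introducing the ring. With no evidence for a direction, no step beyond the scatter is expected in this assay. The expected change is a step that the limit leaves unreadable from compound 2 to compound 3.

For compound 3 the estimated value is 8 mL.min-1.g-1, with an expected range from 4 mL.min-1.g-1 to 18 mL.min-1.g-1. The assay may well report only a limit again.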

Compound 3, intrinsic clearance in microsomes: < 10 mL.min-1.g-1
Compound 3 gave a limit, no number (the forecaster's own chance of this, stated with the estimate: 65%); the middle value is on the limit's open side.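

Compound 1, compound 2 and compound 3 each gave only a limit in this assay, so no step among these three compounds can be read: the limit of < 10 mL.min-1.g-1 in this assay, at which 3 of the 3 values shown sit.

The compounds shown leave open how far their clearance values lie apart, and whether morpholin-4-yl in place of isopropylamino on a sulfonyl sulfur changes clearance at all.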